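Swapping a benzylamino for a dimethylamino on a nucleoside core

A few compounds are considered here, and "the series" means these few. Any claim that something is new, unique, unknown or untested is made for them only; others in the source may bear on it.

Measured compounds:
compound 1 `OC[C@H]1O[C@@H](n2cnc3c(NCc4ccccc4)nccc32)C[C@@H]1O` gives 8%
compound 2 `[O-][n+]1ccc2c(c1)ncn2[C@H]1C[C@H](O)[C@@H](CO)O1` gives < 5%
compound 3 `c1ccc(CNc2[nH]ccc3ncnc2-3)cc1` gives 57%

In a functional assay on EL4 cells (Mus musculus) for inhibition, tested at 100 uM (a higher number here means more inhibition at the concentration tested (going by the name of the read-out), a lower number less inhibition), compound 1 gives 8%, the lowest of the two numbers reported. Its nearest neighbour is compound 3, whose value of 57% sits higher by a gap that lies beyond the usual scatter. Compound 2 reaches only (the limit of < 5% in this assay, at which 1 of the 3 values shown sits), so its reading is a limit of the assay rather than a number.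

The unmeasured compound 4 `CN(C)c1nccc2c1ncn2[C@H]1C[C@H](O)[C@@H](CO)O1` keeps the core of compound 1 and changes one group: dimethylamino in place of benzylamino on an aromatic carbon. Among the compounds with values here, no pair of measured compounds differs in just one place, so the size of this kind of step has not been seen directly. Since compound 1 already sits low in this assay at 8%, the step is expected to be small, most likely downward or within the scatter. Compound 4 is estimated at 6%, with a likely range from 0% to 20%, which corresponds to an expected step of a number 2 percentage points lower from compound 1 to compound 4 (within the scatter).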

Compound 4, a percentage reported as inhibition, at one concentration (the size of the read-out at that concentration, not a potency): < 5%
Compound 4: no number, only a limit (the forecaster's own chance of this, stated with the estimate: 40%); middle value at least 1 percentage points away from the limit.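

Replacing benzylamino with dimethylamino on an aromatic carbon of the shared core gives the first step read directly at this position in this assay, a number at least 3 percentage points lower from compound 1 to compound 4 (that floor lies within the scatter). The change removes the six-membered aromatic ring of carbon only and the hydrogen-bond donor, and no rise in inhibition follows. Compound 4 gives a limit of the assay and not a number, so the step has a floor but no full size: the limit of < 5% in this assay, at which 2 of the 4 values shown sit.

Going by these compounds, how far the true reading of compound 4 lies from that limit stays open, and with it the real size of the step. Also open, on these data alone, is whether a plain amino group or a longer chain such as phenethylamino on the same carbon would give a reading clear of the limit.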